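From methyl to isopropyl on an aromatic carbon

A few compounds are considered here, and "the series" means these few. Any claim that something is new, unique, unknown or untested is made for them only; others in the source may bear on it.

- compound 1 `CCOc1cc(C)c(-c2cccc(COc3ccc(S(=O)(=O)CC(=O)O)cc3)c2)c(C)c1` with 2.86 measured
- compound 2 `Cc1ccccc1-c1cccc(COc2ccc(S(=O)(=O)CC(=O)O)cc2)c1` with 2.35 measured

In a physicochemical assay for lipophilicity, using the shake flask method, in phosphate buffer, measured as octanol-water partition, with a stated time of 24 h, at pH 7.4, tested at 100 uM (a lower number here means a more polar compound, a higher number a more lipophilic compound), compound 2 gives 2.35 and compound 1 gives 2.86. Compound 2 is the lower of the two, and the gap between them lies beyond the scatter. Compound 3 `CC(C)c1ccccc1-c1cccc(COc2ccc(S(=O)(=O)CC(=O)O)cc2)c1` has not yet been measured. It differs from compound 2 by isopropyl in place of methyl on an aromatic carbon as isopropyl in place of methyl on an aromatic carbon. Among the compounds with values here, no measured pair shows this change, so the expectation rests on the structural change alone. In this assay the expectation is a rise beyond the scatter, estimated as a number 0.65 log units higher from compound 2 to compound 3 (beyond the scatter) on this evidence. Compound 3 is therefore expected at 3 within a range from 2.65 to 3.4 when measured.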

Compound 3, distribution coefficient: 3.18
The estimate for compound 3 lay 0.18 log units below the measured number, and the stated range covers the measured number.
By their numbers in this assay, from the lowest: compound 2; then compound 1; then compound 3.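

Isopropyl in place of methyl on an aromatic carbon, ortho to a large group, gives a number 0.83 log units higher from compound 2 to compound 3 (beyond the scatter) in this assay, the only measured pair that shows this change. It shows that the number at this position moves with the alkyl group alone, with the rest of the structure held the same. No measurement given here bears on what lies behind the size of this step.

The compounds shown leave open how an amine, a carboxylic acid or a longer chain on this aromatic carbon would read in this assay. They also leave open whether the same change gives a similar step on the core of compound 1.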